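The source may report more compounds than this note shows. Statements on the series, on what has been measured and on what is new or still open speak of the compounds shown alone.

Compound 1 `CCCCCCCCCCCCCCCCCC/N=c1\nc(N)c2ncn(Cc3ccccc3)c2c(N)n1`: 5400 nM
Compound 2 `CCCCCCCC/N=c1\nc(N)c2ncn(Cc3ccccc3)c2c(N)n1`: 7450 nM

Going by the values given here, in a functional assay on NCI-H460 cells (Homo sapiens) for antiproliferative activity, read by WST assay, with a stated time of 72 h (on this read-out lower numbers stand for stronger inhibition and higher numbers for weaker inhibition), compound 1 gives 5400 nM and compound 2 gives 7450 nM; the gap between them is a 1.4-fold higher number from compound 1 to compound 2 (0.14 log units; within the scatter), so compound 2 sits within the scatter of its single neighbour. Compound 3 `CCCCCCCC/N=c1\nc(N)c2ncn(Cc3ccc(F)cc3)c2c(N)n1` differs from compound 2 by fluoro in place of hydrogen on an aromatic carbon. Among the compounds with values here, no measured step involves this kind of change; the only step on record concerns chain length and stayed within the scatter. The step is therefore expected to be a 1.0-fold lower number from compound 2 to compound 3 (0.00 log units; within the scatter). Compound 3 is estimated at 7400 nM, with a range from 3500 nM to 16000 nM.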

Compound 3, half-maximal inhibitory concentration: 4700 nM
For compound 3 the middle estimate is 1.6-fold (0.20 log units) above the measured one; measured number inside the range.
By their numbers in this assay, from the lowest: compounds 3, 1 and 2 (each within the scatter of the next).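

In this assay, going from benzyl to 4-fluorobenzyl gives a 1.6-fold lower number from compound 2 to compound 3 (0.20 log units; within the scatter) and so shows that fluoro can stand on this aromatic carbon with no change that can be told from the scatter. Going by these compounds alone, the earlier compounds differed only in the chain, so this is the first reading on the ring. Nothing measured here offers an explanation for this result. Still open, going by these compounds, is whether methoxy or a carboxylic acid at this place would move the number beyond the scatter, and whether fluoro gives the same result alongside the longer chain of compound 1.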